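The compounds below may be only part of what the source reports. "The series", "measured", "known", "first", "only" and "open" are said of these compounds alone.

Measured compounds:
Compound 1, `CCCCCCC(CCO)n1cnc2c(Cl)ncnc21`, gives 11900 nM in a functional assay on HCT-116 cells (Homo sapiens) for antiproliferative activity, read by MTT assay, with a stated time of 48 h; a lower number here means a stronger inhibitor, a higher number a weaker inhibitor.
Compound 2, `CCCCCCC(CCO)n1cnc2c(OC)ncnc21`, reaches only the limit > 50000 nM in this assay.
Compound 3, `CCCCCCC(CCO)n1cnc2c(N)ncnc21`, reaches only the limit > 50000 nM in this assay.

Compound 3 therefore stands at the limit of > 50000 nM in this assay, at which 2 of the 3 values shown sit, so no number is known for it, only that it is a weak inhibitor. The unmeasured compound 4, `CCCCCCCCCCCC(CCO)n1cnc2c(N)ncnc21`, differs from compound 3 by pentyl in place of hydrogen on a saturated chain carbon, seven bonds along the chain from an aromatic nitrogen.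

The measured steps all concern the substituent on the aromatic carbon: an at least 4.2-fold higher number from compound 1 to compound 2 (0.62 log units; beyond the scatter) and an at least 4.2-fold higher number from compound 1 to compound 3 (0.62 log units; beyond the scatter), while a step that the two limits leave unreadable from compound 2 to compound 3. Among the compounds with values here, none of them alters the saturated chain, so none bears directly on the change from compound 3 to compound 4, and no step from chain lengthening is recorded for this series. The starting point being a limit, the step cannot be read with any confidence; the expectation is that compound 4 again lands at or near the limit, with a wide range. Compound 4 is expected at 45000 nM, between 8000 nM and 150000 nM. The expected step is an at least 1.1-fold lower number from compound 3 to compound 4 (0.04 log units; that floor lies within the scatter).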

Compound 4, half-maximal inhibitory concentration: 13400 nM
Estimate against measurement, compound 4: 3.4-fold (0.53 log units) above; the range from low to high includes it.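

In this assay, the saturated chain carbon seven bonds along the chain from an aromatic nitrogen is a position where a change registers: pentyl in place of hydrogen gives an at least 3.7-fold lower number from compound 3 to compound 4 (0.57 log units; beyond the scatter). Within the data shown here, the earlier readable steps concerned only the substituent on the aromatic carbon and went towards weaker inhibition, so this is the first step that comes from the chain and the first towards stronger inhibition. The step stands as a floor and not as a full size because compound 3 has only a limit: the limit of > 50000 nM in this assay, at which 2 of the 4 values shown sit.

From the compounds shown here alone, whether pentyl in place of hydrogen acts in the same way with chloro or methoxy on the aromatic carbon stays open. Also open, going by these compounds, is what a longer chain, or a carboxylic acid at this position, would do.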